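A few compounds are considered here, and "the series" means these few. Any claim that something is new, unique, unknown or untested is made for them only; others in the source may bear on it.

Series notes. Compound 1 `CN(C)CCCCCSC1=Nc2ccccc2C(CC(=O)NCc2ccccc2)N1c1ccc(-c2ccc(F)cc2)cc1` and compound 2 `CN(C)CCCCCSC1=Nc2ccccc2C(CC(=O)NCc2ccc(F)cc2)N1c1ccccc1` share one core; in an assay on cells for inhibition of Voltage-dependent T-type calcium channel subunit alpha-1H (Homo sapiens), read by patch clamp, tested at 10 uM (a higher number here means more inhibition at the concentration tested (going by the name of the read-out), a lower number less inhibition), compound 1 gives 75.6%, while compound 2 gives 7%. Compound 2 thus stands lowest of the two numbers, with compound 1 higher by a gap well beyond the usual scatter of this assay.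

Compound 3 `CN(C)CCCCCSC1=Nc2ccccc2C(CC(=O)NCc2ccc(F)cc2)N1c1ccc(-c2ccc(F)cc2)cc1` remains to be measured. Relative to compound 2 the change is 4-fluorophenyl in place of hydrogen on an aromatic carbon. Since compound 1 also carries a 4-fluorophenyl group on the aromatic ring attached to the core and reaches 75.6%, the step is expected to be large and upward: the estimated step from compound 2 to compound 3 is a number 58 percentage points higher from compound 2 to compound 3 (beyond the scatter). For compound 3 in this assay the expected value is 65%, with a range from 35% to 90%.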

Compound 3, a percentage reported as inhibition, at one concentration (the size of the read-out at that concentration, not a potency): 84.8%
For compound 3 the middle estimate is 19.8 percentage points below the measured one, within the range that was stated.
By their numbers in this assay, from the lowest: compound 2; then compounds 1 and 3 (each within the scatter of the next).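

In this assay, 4-fluorophenyl in place of hydrogen on an aromatic carbon, para to a large group, gives a number 77.8 percentage points higher from compound 2 to compound 3 (beyond the scatter), a single-place step that compounds 1 and 2, which differ in two places, could not provide. Fluoro in place of hydrogen on an aromatic carbon gives a number 9.2 percentage points higher from compound 1 to compound 3 (within the scatter), so with 4-fluorophenyl present this second change makes no readable difference. No measurement on hand accounts for either step.

The compounds shown carry only hydrogen or 4-fluorophenyl at this place, so it remains open whether an unsubstituted phenyl or a morpholine there would give a similar step. The fluoro change is also unread on the parent lacking 4-fluorophenyl, and the dimethylamino chain is constant throughout, leaving a carboxylic acid or a shorter chain there open.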